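The source may report more compounds than this note shows. Statements on the series, on what has been measured and on what is new or still open speak of the compounds shown alone.

Of the compounds shown here, three sharing one core have been measured in an ADME assay on MRC5 cells (Homo sapiens) for inhibition, with a stated time of 72 h; a lower number here means that less compound is needed, a higher number that more compound is needed for the effect. Compound 1 `COc1cccc(OC)c1C(=O)Nc1c[nH]nc1C(=O)N[C@H]1CC[C@H](OC)CC1` gives 31000 nM, and compound 3 `COc1cccc(OC)c1C(=O)Nc1c[nH]nc1C(=O)NCc1ccccc1` gives 50000 nM. These two stand level, as the gap is only a 1.6-fold higher number from compound 1 to compound 3 (0.21 log units; within the scatter). Compound 2 `COc1cccc(OC)c1C(=O)Nc1c[nH]nc1C(=O)NN1CCOCC1` gives > 50000 nM, which is a limit of the assay and not a number.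

Compound 4 `COc1cccc(OC)c1C(=O)Nc1c[nH]nc1C(=O)NCC1CCCCC1` alters compound 3 in one place: cyclohexyl in place of phenyl on a saturated chain carbon bound to an amide-type nitrogen. Within the data shown here, no measured pair makes exactly this swap of an aromatic ring for a non-aromatic one. The closest guide is the change of 4-methoxycyclohexyl to benzyl, which gave a 1.6-fold higher number from compound 1 to compound 3 (0.21 log units; within the scatter). The other steps add little: one is an at least 1.6-fold higher number from compound 1 to compound 2 (0.20 log units; that floor lies within the scatter), and the other is a number no higher from compound 2 to compound 3 (the limit leaves the size open). No step beyond the scatter is therefore expected, though compound 1 at 31000 nM hints at a slight drift towards lower numbers. The expected change is a 1.3-fold lower number from compound 3 to compound 4 (0.10 log units; within the scatter). The estimate for compound 4 is 40000 nM, with an expected range of 20000 nM to 70000 nM.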

Compound 4, half-maximal effective concentration: > 50000 nM
Compound 4 ended at the assay's limit (the forecaster's own chance of this, stated with the estimate: 40%); middle value at least 1.2-fold (0.09 log units) away from the limit.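

In this assay, putting a non-aromatic ring in place of an aromatic one on this saturated chain carbon does not bring the number down: a number no lower from compound 3 to compound 4 (the limit leaves the size open). The other readable step gives an at least 1.6-fold higher number from compound 1 to compound 4 (0.20 log units; that floor lies within the scatter), so cyclohexyl here offers no support for the idea that a non-aromatic ring moves the number lower. The value of compound 4 is a limit of the assay and not a number, so the size of the step from compound 3 and the step from compound 2 cannot be read: the limit of > 50000 nM in this assay, at which 2 of the 4 values shown sit.

From the compounds shown here alone, what stays open is whether any group at this position gives a number clearly inside the range of the assay. An amine or a carboxylic acid on the cyclohexyl ring, or a longer chain carrying that ring, would test this.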